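Pyridinyl amide in place of ethylphenyl on the shared core

This account rests on a few compounds, and the source may have more. Where it says the series, first, only, none or still open, it means among the compounds named here.

Compound 3 `CCc1cccc(NC(=O)CN2CCN(c3ccc(Cl)cn3)CC2)c1` gives 7060 nM in a functional assay on cells for antagonist activity at D(4) dopamine receptor (Homo sapiens), read by TR-FRET and cAMP accumulation, with a stated time of 30 min (on this read-out lower numbers stand for stronger inhibition and higher numbers for weaker inhibition), the second highest of the three numbers shown. Its nearest neighbour is compound 2 `Cc1cccc(NC(=O)CN2CCN(c3ccc(Cl)cn3)CC2)c1`, which gives 4700 nM; the step of a 1.5-fold higher number from compound 2 to compound 3 (0.18 log units; within the scatter) lies within the scatter. Furthest away is compound 1 `O=C(CN1CCN(c2ccccn2)CC1)Nc1cccnc1`, which gives 86500 nM, a far weaker result than compound 3.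

Compound 4 `O=C(CN1CCN(c2ccc(Cl)cn2)CC1)Nc1cccnc1` differs from compound 3 in one place: pyridin-3-yl in place of 3-ethylphenyl on an amide-type nitrogen. Among the measured compounds shown here, no measured step follows this change on its own. Compound 1 carries the same pyridin-3-yl on its amide nitrogen, but it also lacks the chlorine of the shared core of compound 3, so its value cannot be separated into the two contributions. Still, compound 1 and compound 3 together show that the pyridin-3-yl amide with a related core gives a much higher number than the ethylphenyl amide.

The step from compound 3 to compound 4 is therefore expected to raise the number well beyond the scatter, as a 4.2-fold higher number from compound 3 to compound 4 (0.63 log units; beyond the scatter). Compound 4 is estimated at 30000 nM in this assay, with a range from 9000 nM to 90000 nM.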

Compound 4, half-maximal inhibitory concentration: 40000 nM
Beside the measured number, compound 4's estimate is 1.3-fold (0.12 log units) below it, and the stated range covers the measured number.
By their numbers in this assay, from the lowest: compounds 2 and 3 (each within the scatter of the next); then compound 4; then compound 1.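

In this assay, the exchange on the amide-type nitrogen can now be read on its own: pyridin-3-yl in place of 3-ethylphenyl gives a 5.7-fold higher number from compound 3 to compound 4 (0.75 log units; beyond the scatter) and pyridin-3-yl in place of 3-methylphenyl gives an 8.5-fold higher number from compound 2 to compound 4 (0.93 log units; beyond the scatter) so both phenyl amides shown lose ground to the pyridin-3-yl amide by steps beyond the scatter. The chlorine, whose part could not be told from compound 1 alone, can also be read separately: chloro in place of hydrogen on an aromatic carbon gives a 2.2-fold lower number from compound 1 to compound 4 (0.33 log units; beyond the scatter) a smaller step that still lies beyond the scatter. Both places therefore move the number on their own, and the change on the amide-type nitrogen gives the larger step. Nothing given here accounts for either step.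

From the compounds shown here alone, whether chloro in place of hydrogen gives a step of similar size when 3-ethylphenyl sits on the amide-type nitrogen remains open. Also open is what a propyl chain in place of the ethyl, or an amine or a carboxylic acid on that aromatic ring, would give in this assay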